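A methyl added to compound 2

A few compounds are considered here, and "the series" means these few. Any claim that something is new, unique, unknown or untested is made for them only; others in the source may bear on it.

Compound 1 `Cc1ccc(-c2cc3ccccc3c(O)n2)cc1` gives 30200 nM
Compound 2 `Cc1ccc2c(O)nc(-c3ccccc3)cc2c1` gives 1320 nM

Both compounds were tested in a functional assay on A549 cells (Homo sapiens) for cytotoxicity, read by sulforhodamine B assay (a lower number here means a stronger inhibitor, a higher number a weaker inhibitor), and their two numbers lie far apart, well beyond the usual scatter. Compound 2 holds the lower number (1320 nM), which makes it the stronger inhibitor of the pair, while compound 1 sits much higher (30200 nM).

The next compound, compound 3 `Cc1ccc2c(O)nc(-c3ccccc3C)cc2c1`, comes from compound 2 through a single change (methyl in place of hydrogen on an aromatic carbon), with methyl in place of hydrogen on an aromatic carbon. Going by the values given here, no measured pair shows what this change does, so the data offer no direct guide, and the gap between compound 1 and compound 2 cannot be read as a precedent for it. The change is small, so only a small rise in the number is expected, toward a slightly weaker inhibitor and probably within the scatter. The estimated move is modest (a 1.5-fold higher number from compound 2 to compound 3 (0.18 log units; within the scatter)). Compound 3 is expected to read 2000 nM (estimated range 500 nM to 8000 nM).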

Compound 3, half-maximal inhibitory concentration: 5890 nM
For compound 3 the middle estimate is 2.9-fold (0.47 log units) below the measured one; the range from low to high includes it.
By their numbers in this assay, from the lowest: compound 2; then compound 3; then compound 1.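

In this assay, methyl in place of hydrogen on an aromatic carbon, ortho to a large group, is not a neutral change: the series moves by a 4.5-fold higher number from compound 2 to compound 3 (0.65 log units; beyond the scatter) for that one added carbon. Going by these compounds alone, this is the first measured step that isolates a single change in these compounds, and it shows that a single heavy atom at this place on the six-membered aromatic ring of carbon only is enough to carry the number beyond the scatter, toward a weaker inhibitor. Nothing at hand accounts for this loss, so it stands as an observation without an explanation.

The compounds shown leave open whether the loss belongs to methyl itself or would follow any group on this carbon, a question that a fluorine atom, a methoxy group or an amine at the same place would begin to answer. They also leave open whether a methyl on another carbon of the same ring would cost as much, or whether the loss is tied to this one place.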